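This account rests on a few compounds, and the source may have more. Where it says the series, first, only, none or still open, it means among the compounds named here.

Compound 1 `Nc1ncnc2c1c(Oc1cc(C(F)(F)F)ccn1)nn2C1CCC1` gives 0.128 h in an ADME assay on microsomes from liver (Mus musculus) for metabolic stability, read by LC-MS, using NADPH, with a stated time of 10 min, tested at 10 uM; a higher number here means that the compound lasts longer, a lower number that the compound disappears faster.
Compound 2 `Nc1ncnc2c1c(Oc1cc(C(F)(F)F)ccn1)nn2[C@H]1CC[C@@H](CO)CC1` gives 0.108 h in this assay.
Compound 3 `Nc1ncnc2c1c(Oc1cc(C(F)(F)F)ccn1)nn2C1CC1` gives > 2.41 h in this assay.

For compound 3 the value is a limit of this assay and not a number; it sits at the limit of > 2.41 h in this assay, at which 1 of the 3 values shown sits, so only the floor of its stability is known. Compound 4 `Nc1ncnc2c1c(Oc1cc(C(F)(F)F)ccn1)nn2[C@@H]1CCCC[C@H]1O` differs from compound 3 by 2-hydroxycyclohexyl in place of cyclopropyl on an aromatic nitrogen. Among the measured compounds shown here, two measured steps bear on this change: an at least 18-fold higher number from compound 1 to compound 3 (1.27 log units; beyond the scatter) and an at least 22-fold higher number from compound 2 to compound 3 (1.34 log units; beyond the scatter). Both exchanges toward cyclopropyl produced large rises, and compound 2, which carries 4-(hydroxymethyl)cyclohexyl, sits at the low end. Moving away from cyclopropyl to 2-hydroxycyclohexyl is therefore expected to give a large fall, an at least 16-fold lower number from compound 3 to compound 4 (1.20 log units; beyond the scatter). Compound 4 is estimated at 0.15 h, with a range from 0.05 h to 0.6 h.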

Compound 4, half-life in the Mus musculus assay: 1.1 h
The estimate for compound 4 lay 7.3-fold (0.87 log units) below the measured number; the whole stated range lies below it.
By their numbers in the Mus musculus assay, from the lowest: compounds 2 and 1 (each within the scatter of the next); then compound 4. At a limit, above all of these: compound 3.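

On the aromatic nitrogen, a six-membered ring need not mean a short half-life in the Mus musculus assay, since 2-hydroxycyclohexyl gives a 10-fold higher number from compound 2 to compound 4 (1.01 log units; beyond the scatter) and an 8.6-fold higher number from compound 1 to compound 4 (0.93 log units; beyond the scatter). Against cyclopropyl the change gives an at least 2.1-fold lower number from compound 3 to compound 4 (0.34 log units; beyond the scatter), and this step rests on a limit for compound 3, not on a number. In a physicochemical assay for solubility, read by HPLC, in phosphate buffer, measured as kinetic solubility, with a stated time of 24 h, at pH 7.4 (on this read-out lower numbers stand for lower solubility and higher numbers for higher solubility), compound 3 gives 191000 nM and compound 4 gives 92700 nM, so compound 4 also stands lower on solubility.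

Still open, on these data alone, is whether the rise over compounds 1 and 2 follows the hydroxy group, its place on the ring or the 2 defined stereocentres. Plain cyclohexyl or 2-aminocyclohexyl would help to separate these.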